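Aryl replacement on the saturated ring carbon: compounds 1 to 4

The source may report more compounds than this note shows. Statements on the series, on what has been measured and on what is new or still open speak of the compounds shown alone.

Measured so far in a functional assay on thoracic aorta for inhibition of Voltage-gated L-type calcium channel (Rattus norvegicus); a lower number here means a stronger inhibitor, a higher number a weaker inhibitor:
compound 1 `CC1=NC(C)=C(C(=O)O)C(c2ccc([N+](=O)[O-])cc2)/C1=C(\O)OC/C=C/c1ccccc1` gives 1600 nM
compound 2 `CC1=NC(C)=C(C(=O)O)C(c2ccccc2)/C1=C(\O)OC/C=C/c1ccccc1` gives 9 nM
compound 3 `CC1=NC(C)=C(C(=O)O)C(c2cccc(C)c2)/C1=C(\O)OC/C=C/c1ccccc1` gives 76 nM

Compound 3 stands second highest of the three numbers. Its nearest neighbour is compound 2, the step being an 8.4-fold higher number from compound 2 to compound 3 (0.93 log units; beyond the scatter), a modest one, while the far neighbour is compound 1, with a 21-fold lower number from compound 1 to compound 3 (1.32 log units; beyond the scatter), a large one. The third step, a 180-fold lower number from compound 1 to compound 2 (2.25 log units; beyond the scatter), is also large; all three steps change the group on the same saturated ring carbon, and the numbers there spread widely.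

Compound 4 `CC1=NC(C)=C(C(=O)O)C(c2ccsc2)/C1=C(\O)OC/C=C/c1ccccc1` differs from compound 3 by thiophen-3-yl in place of 3-methylphenyl on a saturated ring carbon. For the measured compounds named here, no measured compound carries a five-membered ring at this position, so the bearing of the known steps is indirect. The entering thiophen-3-yl lacks both the nitro that made compound 1 weak and the methyl of compound 3; the outcome is therefore expected to sit between compound 2 and compound 3, a small move downwards beyond the scatter. The expected step is a 2.5-fold lower number from compound 3 to compound 4 (0.40 log units; beyond the scatter). Compound 4 is expected near 30 nM, with a range from 8 nM to 120 nM.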

Compound 4, half-maximal inhibitory concentration: 44 nM
Estimate against measurement, compound 4: 1.5-fold (0.17 log units) below; the measured number falls inside the stated range.
By their numbers in this assay, from the lowest: compound 2; then compounds 4 and 3 (each within the scatter of the next); then compound 1.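

In this assay, the saturated ring carbon also accepts a five-membered aromatic ring with one sulfur atom: with a 1.7-fold lower number from compound 3 to compound 4 (0.24 log units; within the scatter), thiophen-3-yl and 3-methylphenyl cannot be told apart, despite their different ring sizes. Plain phenyl keeps its edge over the new ring, with a 4.9-fold higher number from compound 2 to compound 4 (0.69 log units; beyond the scatter), so compound 2 remains the only one clear of all the others at this position. Thiophen-3-yl does not share the weakness seen with 4-nitrophenyl, as a 36-fold lower number from compound 1 to compound 4 (1.56 log units; beyond the scatter) shows, but no measurement shown accounts for any of these differences.

As far as these compounds go, it remains open whether the weak value of compound 1 is specific to nitro or would recur with an amine or a methoxy group on the phenyl ring. Also open, from the compounds shown here alone, is whether furan-3-yl or pyridin-3-yl on this carbon would match thiophen-3-yl.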